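From Isopropyl Ether to Methoxyethyl Ether

The compounds below may be only part of what the source reports. "The series", "measured", "known", "first", "only" and "open" are said of these compounds alone.

compound 1, `COc1cc(C)c(-c2cccc(COc3ccc(OCC(=O)O)c(F)c3)c2)c(C)c1`: 3.2
compound 2, `Cc1cc(OC(C)C)cc(C)c1-c1cccc(COc2ccc(OCC(=O)O)c(F)c2)c1`: "not determined" (no result reported)
compound 3, `COCCOc1cc(C)c(-c2cccc(COc3ccc(OCC(=O)O)c(F)c3)c2)c(C)c1`: to be measured

All three share one core and were compared in a physicochemical assay for lipophilicity, using the shake flask method, in phosphate buffer, measured as octanol-water partition, with a stated time of 24 h, at pH 7.4, tested at 100 uM; on this read-out higher numbers stand for higher lipophilicity and lower numbers for lower lipophilicity. Compound 1 gives 3.2. For compound 2 the result in this assay is "not determined" (no result reported), so compound 2 stands on no single number. Compound 3 differs from compound 2 by 2-methoxyethyl in place of isopropyl on an oxygen on an aromatic ring. Going by the values given here, no pair of measured compounds sets the size of this step; the expectation is a shift in this assay no larger than the usual scatter, in either direction. Taking the value of compound 1, 3.2, as the nearest anchor, compound 3 is estimated at 3.3, within 2.8 to 3.8.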

Compound 3, distribution coefficient: 3.15
Beside the measured number, compound 3's estimate is 0.15 log units above it; low and high end bracket the measured number.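

In this assay, methoxymethyl in place of hydrogen on a saturated chain carbon bound to an oxygen on an aromatic ring gives a number 0.05 log units lower from compound 1 to compound 3 (within the scatter), so this position accepts the 2-methoxyethyl group, with its added oxygen, without a reading that stands apart from the smaller ether. The step from isopropyl to 2-methoxyethyl cannot be read, since compound 2 has no number. No measurement on hand explains this result.

Going by these compounds, whether an amine or a carboxylic acid in place of the 2-methoxyethyl would leave the reading level remains open. So does the effect of a longer chain.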